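This account rests on a few compounds, and the source may have more. Where it says the series, first, only, none or still open, it means among the compounds named here.

In an ADME assay on cells (Rhabdomyosarcoma cell, Homo sapiens) for cytotoxicity, read by MTT assay, with a stated time of 72 h (a higher number here means that more compound is tolerated, a lower number that less compound is tolerated), compound 3 `Clc1ccccc1/C=N/c1sc2c(c1-c1nc3ccccc3s1)CCCC2` gives 332 ug/mL, the highest of the three numbers recorded, though only part of that lead counts. Compound 1 `Fc1ccc(/C=N/c2sc3c(c2-c2nc4ccccc4s2)CCCC3)cc1` gives 230 ug/mL, which lies within the scatter of compound 3, while compound 2 `C(=N/c1sc2c(c1-c1nc3ccccc3s1)CCCC2)\c1ccccc1` gives 71.1 ug/mL, a gap beyond it. Compound 4 `O=[N+]([O-])c1ccccc1/C=N/c1sc2c(c1-c1nc3ccccc3s1)CCCC2` differs from compound 3 by one change: nitro in place of chloro on an aromatic carbon. For the measured compounds named here, no measured step swaps chloro for nitro, but two steps alter the same aromatic position: a 3.2-fold lower number from compound 1 to compound 2 (0.51 log units; beyond the scatter) and a 4.7-fold higher number from compound 2 to compound 3 (0.67 log units; beyond the scatter), so each time a halogen stood there the tolerated concentration was modestly higher. On these data alone, whether nitro follows the halogens or the bare hydrogen is unknown, so compound 4 is expected to shift little, if at all, beyond the scatter: a 1.3-fold lower number from compound 3 to compound 4 (0.12 log units; within the scatter). The estimate for compound 4 is 250 ug/mL, with a range from 100 ug/mL to 600 ug/mL.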

Compound 4, half-maximal cytotoxic concentration: 255 ug/mL
Estimate against measurement, compound 4: 1.0-fold (0.01 log units) below; measured number inside the range.
By their numbers in this assay, from the lowest: compound 2; then compounds 1, 4 and 3 (each within the scatter of the next).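

In this assay, for the compounds shown here, nitro, with three heavy atoms, can replace the single chlorine with no change beyond the scatter (a 1.3-fold lower number from compound 3 to compound 4 (0.11 log units; within the scatter)). Compared with the bare hydrogen, the step is beyond the scatter (a 3.6-fold higher number from compound 2 to compound 4 (0.55 log units; beyond the scatter)), while compound 4 remains within the scatter of the 4-fluorophenyl compound (a 1.1-fold higher number from compound 1 to compound 4 (0.04 log units; within the scatter)), so this position is not limited to halogens for matching compounds 1 and 3, with compound 2 alone apart. No available evidence accounts for this pattern.

On these data alone, whether an amine or a carboxylic acid on this aromatic carbon would group with compounds 1, 3 and 4 or with compound 2 remains open.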